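The compounds below may be only part of what the source reports. "The series", "measured", "known", "first", "only" and "open" are said of these compounds alone.

Measured so far:
compound 1, `CCOC(=O)C(C)Sc1nncc2cncn12`, in a functional assay for inhibition, with Homo sapiens as the target (a lower number here means a stronger inhibitor, a higher number a weaker inhibitor), gives > 48000 nM
compound 2, `CCOC(=O)CSc1nncc2c(C)ncn12`, in this assay gives > 48000 nM

Compound 2 stands at the top of what this assay reports: its value is a limit, not a number. Compound 1 also sits at a limit in this assay. Among the measured compounds shown here, both measured compounds therefore share (the limit of > 48000 nM in this assay, at which 2 of the 2 values shown sit), so no step between measured compounds is known and no direction of change can be read from them.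

Compound 3, `CCOC(=O)CSc1nncc2cncn12`, remains to be measured. It differs from compound 2 by hydrogen in place of methyl on an aromatic carbon. Compound 1 likewise lacks that methyl and gives a limit of > 48000 nM in this assay. The step from compound 2 to compound 3 is expected to be a step that the limit leaves unreadable from compound 2 to compound 3, none beyond the scatter. Compound 3 is estimated at 80000 nM, within 20000 nM to 400000 nM, most likely reported again only as a limit.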

Compound 3, half-maximal inhibitory concentration: > 48000 nM
Compound 3: a limit, no number (the forecaster's own chance of this, stated with the estimate: 85%); the middle value does not contradict the limit.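

Neither the step from compound 2 to compound 3 nor the step from compound 1 to compound 3 can be read in this assay, because all three compounds sit at a limit: the limit of > 48000 nM in this assay, at which 3 of the 3 values shown sit.

The compounds shown leave open whether either methyl placement changes inhibition at all, since none gives a numerical value.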